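A few compounds are considered here, and "the series" means these few. Any claim that something is new, unique, unknown or untested is made for them only; others in the source may bear on it.

Among the compounds with values here, the two compounds measured so far share one core. Compound 1 `COc1ccc(Cl)cc1C(=O)Nc1ccc(C2=NN(C)C(c3ccccc3[N+](=O)[O-])C2)cc1` carries a methyl group on a ring nitrogen and a 2-nitrophenyl group on a saturated ring carbon. In a functional assay on the whole organism (strain albino) with Rattus norvegicus as the target, read by paw edema, with stated times of 1 h and 4 h, at a dose of 25 mg/kg by the oral route (a higher number here means a stronger effect of the compound at the dose given, a lower number a weaker effect), compound 1 gives 96.5%, the highest of the two numbers seen, though the next number lies within the scatter. Compound 2 `COc1ccc(Cl)cc1C(=O)Nc1ccc(C2=NN(C)C(c3ccc([N+](=O)[O-])cc3)C2)cc1` differs only in the position of the nitro group on that phenyl ring, and in this assay compound 2 gives 93%. The step of a number 3.5 percentage points lower from compound 1 to compound 2 (within the scatter) is within the scatter, so moving the nitro group around that ring changes little.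

Compound 3 `COc1ccc(Cl)cc1C(=O)Nc1ccc(C2=NN(c3ccccc3)C(c3ccccc3[N+](=O)[O-])C2)cc1` has not yet been measured. It differs from compound 1 as follows: phenyl in place of methyl on an amine nitrogen in a ring. Within the data shown here, no measured step touches the ring nitrogen, so nothing in the data speaks directly to this change; the only step available concerns a different part of the molecule. Compound 1 already sits close to full activity, leaving little room upward. Compound 3 is therefore expected to give about 85%, somewhere between 65% and 98%, an expected step of a number 11.5 percentage points lower from compound 1 to compound 3 (beyond the scatter).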

Compound 3, a percentage reported as activity, at one dose (the size of the read-out at that dose, not a potency): 80.2%
For compound 3 the middle estimate is 4.8 percentage points above the measured one; low and high end bracket the measured number.
By their numbers in this assay, from the lowest: compound 3; then compounds 2 and 1 (each within the scatter of the next).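

Placing phenyl instead of methyl on the amine nitrogen in the ring gives a number 16.3 percentage points lower from compound 1 to compound 3 (beyond the scatter) in this assay, the first step here that lies beyond the usual scatter, whereas moving the nitro group gave only a number 3.5 percentage points lower from compound 1 to compound 2 (within the scatter). This shows that the group on this ring nitrogen can change the read-out, although the effect is far from lost, since compound 3 still gives 80.2% at the same oral dose. The data offer no measurement that would explain the drop.

Going by these compounds, with only methyl and phenyl on this nitrogen, a single pair cannot show a trend with group size, so it remains open whether an ethyl group, a longer chain or a benzyl group would give a number closer to that of compound 1 or that of compound 3. On these data alone, it is also open whether the same exchange would cost as much with the 4-nitrophenyl group of compound 2 on the saturated ring carbon.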